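Removing a Methoxy Group from a Diarylpropane Scaffold

A few compounds are considered here, and "the series" means these few. Any claim that something is new, unique, unknown or untested is made for them only; others in the source may bear on it.

The account concerns two measured compounds and one that awaits measurement. Compound 1 `COc1cc(/C=C/C(=O)c2cccc(O)c2)ccc1O` is a chalcone bearing a free phenol on each aryl ring; in an ADME assay on RAW264.7 cells (Mus musculus) for cytotoxicity, read by MTT assay, with a stated time of 24 h, tested at 2.5 ug/mL (a lower number here means a stronger effect, a higher number a weaker effect of the compound at the concentration tested), compound 1 gives 94%. Compound 2 `COc1ccc(CCCc2ccc(OC)c(OC)c2)c(O)c1` is a saturated three-carbon-linked diarylpropane with three methoxy groups and one phenol; in this assay compound 2 gives 91.7%. Compound 2 holds the lowest of the two numbers, and its nearest neighbour is compound 1, whose number is higher by an amount within the scatter, so the two compounds cannot be ordered.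

Compound 3 `COc1ccc(CCCc2ccc(OC)cc2O)cc1` differs from compound 2 by a single change: hydrogen in place of methoxy on an aromatic carbon. Within the data shown here, no measured pair in this set shows such a change, so no measured step tells how large its effect is. Given that both measured compounds sit close together near the top of the scale, compound 3 is expected to behave much like compound 2, with a step of a number 0.3 percentage points higher from compound 2 to compound 3 (within the scatter) that is estimated to lie within the scatter. Compound 3 is accordingly estimated at 92%, with a range from 82% to 100%.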

Compound 3, a percentage reported as activity, at one concentration (the size of the read-out at that concentration, not a potency): 96.8%
Compound 3: middle estimate off by 4.8 percentage points, on the low side; the range from low to high includes it.
By their numbers in this assay, from the lowest: compounds 2, 1 and 3 (each within the scatter of the next).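

In this assay, among these compounds, hydrogen in place of methoxy on an aromatic carbon gives a number 5.1 percentage points higher from compound 2 to compound 3 (within the scatter), and this is the first step in the set that can be read for any change on the shared core. It shows that, at this position, ortho to a methoxy group and meta to a large group, the methoxy can be exchanged for hydrogen with a step that stays within the scatter, so compound 2 and compound 3 cannot be ordered in this read-out at the concentration tested. No information in the set bears on why the step has this size.

The compounds shown leave open whether this tolerance extends to other groups at the same place, such as an amine, a carboxylic acid or a longer chain like butoxy, since hydrogen and methoxy are the only two substituents seen here. They also leave open whether exchanging one of the other methoxy groups, or the phenol, would give a similar step, and whether this single pair would hold at a higher concentration.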